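The source may report more compounds than this note shows. Statements on the series, on what has been measured and on what is new or still open speak of the compounds shown alone.

Working notes on the series. Compound 1 `CC(=O)OC(C)n1cnc2c(Cl)nc(F)nc21` gives 93300 nM in a functional assay (Homo sapiens) for inhibition; on this read-out lower numbers stand for stronger inhibition and higher numbers for weaker inhibition. Compound 2 `CC(=O)OC(C)n1cnc2c(S)nc(N)nc21` gives 25000 nM in this assay. Compound 3 `CC(=O)OC(C)n1cnc2c(S)nc(F)nc21` reaches only a limit, > 500000 nM in this assay, which is the limit of > 500000 nM in this assay, at which 1 of the 3 values shown sits. Compound 3 therefore sits at the weak end of the numbers shown: an at least 5.3-fold higher number from compound 1 to compound 3 (0.72 log units; beyond the scatter) and an at least 20-fold higher number from compound 2 to compound 3 (1.30 log units; beyond the scatter). Compound 4 `CC(O)n1cnc2c(S)nc(F)nc21` differs from compound 3 by hydrogen in place of acetyl on an oxygen on a saturated carbon. Within the data shown here, neither measured step touches this oxygen; both concern groups on an aromatic carbon, so no step of known size bears on the change. No shift beyond the scatter in this assay is expected, and compound 4 is expected to remain at or near the limit. Compound 4 is estimated at 700000 nM, between 200000 nM and 3000000 nM, an expected step that the limit leaves unreadable from compound 3 to compound 4.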

Compound 4, half-maximal inhibitory concentration: > 500000 nM
Compound 4: a limit, no number; the forecaster's own chance of this, stated with the estimate: 70%; the middle value is on the limit's open side.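

Compound 3 and compound 4 both stop at a limit rather than a number, so no step between them can be read: the limit of > 500000 nM in this assay, at which 2 of the 4 values shown sit.

The compounds shown leave open what acetoxy to hydroxy does in this assay when the starting compound gives a measurable number.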